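Bromination of the Anilino Ring, Repeated on a Second Core

The compounds below may be only part of what the source reports. "The series", "measured", "known", "first", "only" and "open" are said of these compounds alone.

Compound 1 `CC(=O)C[C@H]1O[C@@H](On2cc(CN3C(=O)/C(=N\Nc4ccccc4)c4ccccc43)nn2)[C@H](OC(C)=O)[C@@H](OC(C)=O)[C@H]1OC(C)=O` and compound 2 `CC(=O)C[C@H]1O[C@@H](On2cc(CN3C(=O)/C(=N\Nc4ccc(Br)cc4)c4ccccc43)nn2)[C@H](OC(C)=O)[C@@H](OC(C)=O)[C@H]1OC(C)=O` share one core and differ in a single place: bromo in place of hydrogen on an aromatic carbon. Compound 3 `O=C1/C(=N\Nc2ccccc2)c2ccccc2N1Cc1cn(O[C@@H]2O[C@H](CO)[C@H](O)[C@H](O)[C@H]2O)nn1` is built on another core; the difference between the two cores is not broken down here. Compound 4 `O=C1/C(=N\Nc2ccc(Br)cc2)c2ccccc2N1Cc1cn(O[C@@H]2O[C@H](CO)[C@H](O)[C@H](O)[C@H]2O)nn1`, not yet measured, stands to compound 3 exactly as compound 2 stands to compound 1: bromo in place of hydrogen on an aromatic carbon. The place of the change is described in the same words in both pairs, so the change is the same one, made twice among these four compounds.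

In an ADME assay on Vero cells (Chlorocebus sabaeus) for cytotoxicity, read by fluorescence and resazurin assay, with a stated time of 3 days (a higher number here means that more compound is tolerated, a lower number that less compound is tolerated), compound 1 gives 65200 nM. In this assay compound 2 gives 83400 nM. The step between them, a 1.3-fold higher number from compound 1 to compound 2 (0.11 log units; within the scatter), is small. Compound 3 gives 83400 nM in this assay, a number within the scatter of that of compound 2 and within the scatter of that of compound 1 as well; no order among the three measured compounds can be read from these numbers.

Among the measured compounds shown here, for compound 4 the expectation rests on the one earlier instance of this change. The step from compound 3 is expected to be a 1.2-fold higher number from compound 3 to compound 4 (0.08 log units; within the scatter), because the same change gave a 1.3-fold higher number from compound 1 to compound 2 (0.11 log units; within the scatter) on the first core. Compound 4 is therefore estimated to give 100000 nM in this assay, with a likely range from 50000 nM to 200000 nM.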

Compound 4, half-maximal cytotoxic concentration: 91500 nM
The estimate for compound 4 lay 1.1-fold (0.04 log units) above the measured number; low and high end bracket the measured number.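

In this assay the new step is small, a 1.1-fold higher number from compound 3 to compound 4 (0.04 log units; within the scatter), and it can be set beside the one seen earlier on the other core: the same change on two cores in this assay, a 1.3-fold higher number (0.11 log units; within the scatter) from compound 1 to compound 2 and a 1.1-fold higher number (0.04 log units; within the scatter) from compound 3 to compound 4, 1.2-fold (0.07 log units) apart, within the scatter of two such steps. Bromo in place of hydrogen on an aromatic carbon therefore read alike on the two cores: on neither did it move the number beyond the scatter, and the two steps cannot be told apart. Among the compounds shown here, this does not show that an effect of measurable size carries from one core to the other; the agreement is between two steps that are both within the scatter, and it rests on only two pairs and a single read-out.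

The compounds shown leave open whether a different group at the same place, para to a large group, such as chloro, methoxy, an amine or a carboxylic acid, would give a step beyond the scatter on either core. They also leave open whether a longer chain there would behave alike on the two cores, and whether a change that does move the number on one core would carry over to the other.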